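The source may hold more compounds than are shown below. What is called first, only, known or untested is meant among the compounds shown, and "the series" means these compounds.

Compound 1 `CC(C)NC(=O)N1CCC(CN(C2Cc3cc(C#N)ccc3N(Cc3cncn3C)C2)S(=O)(=O)c2ccccn2)CC1` gives 0.6 10^-6 cm/s in an ADME assay on Caco-2 cells (Homo sapiens) for permeability, in the apical to basolateral direction; on this read-out lower numbers stand for lower permeability and higher numbers for higher permeability. Compound 3 `CCNC(=O)N1CCC(CN(C2Cc3cc(C#N)ccc3N(Cc3cncn3C)C2)S(=O)(=O)c2ccccn2)CC1` gives 0.6 10^-6 cm/s, and no change at the digits printed from compound 1 to compound 3 (within the scatter); together the two stand highest of the three numbers measured. Compound 2 `CCS(=O)(=O)N1CCC(CN(C2Cc3cc(C#N)ccc3N(Cc3cncn3C)C2)S(=O)(=O)c2ccccn2)CC1` gives 0.1 10^-6 cm/s, the lowest of the set. Compound 4 `Cn1cncc1CN1CC(N(CC2CCN(S(=O)(=O)c3ccccc3)CC2)S(=O)(=O)c2ccccn2)Cc2cc(C#N)ccc21` differs from compound 1 by phenylsulfonyl in place of isopropylcarbamoyl on an amine nitrogen in a ring. Among the compounds with values here, two measured steps bear on this change, both exchanging a carbamoyl for a sulfonyl on the same ring nitrogen: a 6.0-fold lower number from compound 1 to compound 2 (0.78 log units; beyond the scatter), and in the reverse sense a 6.0-fold higher number from compound 2 to compound 3 (0.78 log units; beyond the scatter). A sulfonyl entering at that position therefore points to a lower number, and the step is expected to be a 3.0-fold lower number from compound 1 to compound 4 (0.48 log units; beyond the scatter). Compound 4 is estimated at 0.2 10^-6 cm/s, with a range from 0.05 10^-6 cm/s to 0.7 10^-6 cm/s.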

Compound 4, apparent permeability: 0.1 10^-6 cm/s
Compound 4: the middle estimate sits 2.0-fold (0.30 log units) above what was measured; the measured number falls inside the stated range.
By their numbers in this assay, from the lowest: compounds 2 and 4 (each within the scatter of the next); then compounds 1 and 3 (each within the scatter of the next).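

With phenylsulfonyl on the ring nitrogen, the number falls as it did with ethylsulfonyl: a 6.0-fold lower number from compound 1 to compound 4 (0.78 log units; beyond the scatter) and a 6.0-fold lower number from compound 3 to compound 4 (0.78 log units; beyond the scatter). The group on the sulfonyl sulfur matters little here, with no change at the digits printed from compound 2 to compound 4 (within the scatter). Across these four compounds, both carbamoyls stand above both sulfonyls, and no compound goes against this split.

Nothing shown gives a reason for the split. On these data alone, whether an acetyl group or a plain methyl on that ring nitrogen would stand with the carbamoyls or with the sulfonyls stays open.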